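Sulfonyl aryl variation and hepatic clearance in one series

The source may hold more compounds than are shown below. What is called first, only, known or untested is meant among the compounds shown, and "the series" means these compounds.

Measured so far:
compound 1, `COc1cccc(-c2c(S(=O)(=O)c3ccc(OC)c(Cl)c3)cnc3cc(F)ccc23)c1`: 1.71 mL/min
compound 2, `Cc1ccc(S(=O)(=O)c2cnc3cc(F)ccc3c2-c2ccc(F)cc2)cc1C`: 9.25 mL/min
compound 3, `COc1cccc(-c2c(S(=O)(=O)c3cc(F)cc(F)c3)cnc3cc(F)ccc23)c1`: 1.81 mL/min

All three numbers come from an ADME assay on microsomes from liver (Homo sapiens) for metabolic stability, tested at 2.5 uM; on this read-out higher numbers stand for fast clearance and lower numbers for slow clearance. Compound 3 stands second highest of the three; its nearest neighbour is compound 1, and the gap between the two is within the scatter, while compound 2 lies well beyond the scatter above it.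

The next compound is compound 4, `COc1cccc(-c2c(S(=O)(=O)c3ccc(C)c(C)c3)cnc3cc(F)ccc23)c1`. Relative to compound 3 the change is 3,4-dimethylphenyl in place of 3,5-difluorophenyl on a sulfonyl sulfur. Going by the values given here, only one measured step alters the group on the sulfonyl sulfur: a 1.1-fold higher number from compound 1 to compound 3 (0.02 log units; within the scatter). That step does not reach beyond the scatter. Among the compounds with values here, compound 2 carries the same 3,4-dimethylphenyl on the sulfonyl sulfur as compound 4, but it also differs from compound 3 in a second place, so no single step links it to compound 3; its value is simply the highest of the three.

For compound 4 the expectation in this assay is therefore a moderate rise, a 2.2-fold higher number from compound 3 to compound 4 (0.34 log units; beyond the scatter), with wide uncertainty. The estimate for compound 4 is 4 mL/min, expected to fall between 1.8 mL/min and 9 mL/min.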

Compound 4, intrinsic clearance in a liver preparation (reported as CLH), per the amount of preparation that the assay uses: 8.78 mL/min
The estimate for compound 4 lay 2.2-fold (0.34 log units) below the measured number, within the range that was stated.
By their numbers in this assay, from the lowest: compounds 1 and 3 (each within the scatter of the next); then compounds 4 and 2 (each within the scatter of the next).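

In this assay, going by these compounds alone, the group on the sulfonyl sulfur does move the number: 3,4-dimethylphenyl in place of 3,5-difluorophenyl gives a clear rise (a 4.9-fold higher number from compound 3 to compound 4 (0.69 log units; beyond the scatter)), and 3,4-dimethylphenyl in place of 3-chloro-4-methoxyphenyl gives a rise of similar size (a 5.1-fold higher number from compound 1 to compound 4 (0.71 log units; beyond the scatter)), whereas the one earlier step on this sulfur stayed within the scatter. The group on the aromatic carbon shows no such effect with 3,4-dimethylphenyl on the sulfonyl sulfur, since 3-methoxyphenyl in place of 4-fluorophenyl stays within the scatter (a 1.1-fold lower number from compound 2 to compound 4 (0.02 log units; within the scatter)). Nothing on hand speaks to the cause of the rise.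

The rise could go with the two methyl groups gained or with the two fluorines lost, and a 3,5-dimethylphenyl or a 4-methylphenyl on the sulfonyl sulfur would help to separate these readings. As far as these compounds go, it also remains open whether 4-fluorophenyl and 3-methoxyphenyl stay level with 3,5-difluorophenyl on the sulfonyl sulfur, and how an aryl group carrying an amine or a carboxylic acid would read in this assay on the same sulfur.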